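The source may hold more compounds than are shown below. What is called first, only, known or untested is meant among the compounds shown, and "the series" means these compounds.

Working notes on the series. For the measured compounds named here, in a functional assay on NCI-H1975 cells (Homo sapiens) for inhibition, read by sulforhodamine B assay, tested at 10 uM (on this read-out lower numbers stand for less inhibition and higher numbers for more inhibition at the one concentration tested (going by the name of the read-out)), compound 1 `CN(C)c1ccc(C2CC(c3ccc(-n4ccnc4)cc3)=NN2)cc1` gives 0.1%, while compound 2 `CN(C)c1ccc(C2CC(c3ccc(-n4ccnc4)cc3)=NN2C(=O)c2cc(Cl)cc(Cl)c2)cc1` gives 58.7%, the highest of the two numbers; the step of a number 58.6 percentage points higher from compound 1 to compound 2 (beyond the scatter) is the only measured step, and it lies beyond the scatter. Compound 3 `CN(C)c1ccc(C2CC(c3ccc(-n4ccnc4)cc3)=NN2S(C)(=O)=O)cc1` differs from compound 2 by methylsulfonyl in place of (3,5-dichlorophenyl)carbonyl on an amine nitrogen in a ring. This step bears only a loose kinship to the measured one, since a substituent on the ring nitrogen is retained but changes; a downward step in this assay is expected, about a number 28.7 percentage points lower from compound 2 to compound 3 (beyond the scatter). Compound 3 is therefore estimated at 30%, with a range from 5% to 60%.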

Compound 3, a percentage reported as inhibition, at one concentration (the size of the read-out at that concentration, not a potency): -3.8%
Estimate against measurement, compound 3: 33.8 percentage points above; measured number outside the range, below it.
By their numbers in this assay, from the lowest: compounds 3 and 1 (each within the scatter of the next); then compound 2.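

At the amine nitrogen in the ring, in this assay, a substituent alone does not raise the number: methylsulfonyl in place of hydrogen gives a number 3.9 percentage points lower from compound 1 to compound 3 (within the scatter), whereas methylsulfonyl in place of (3,5-dichlorophenyl)carbonyl gives a number 62.5 percentage points lower from compound 2 to compound 3 (beyond the scatter). Of the groups shown at this position, only (3,5-dichlorophenyl)carbonyl goes with a raised number. Nothing at hand explains this difference between the two groups.

The compounds shown leave open whether the read-out follows the carbonyl, the aromatic ring or the two chlorines. An acetyl group, an unsubstituted benzoyl group and a (3,5-dichlorophenyl)sulfonyl group on this nitrogen would separate these parts.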